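The source may hold more compounds than are shown below. What is called first, only, known or untested is meant among the compounds shown, and "the series" means these compounds.

Compounds measured in an assay on isolated protein for inhibition of histone deacetylase 8 (Homo sapiens), read by fluorescence, with a stated time of 10 min; a higher number here means a weaker inhibitor, a lower number a stronger inhibitor:
compound 1 `O=C(CCCCCCc1nc(-c2cccc([N+](=O)[O-])c2)no1)NO`: 2380 nM
compound 2 `Nc1ccccc1NC(=O)CCCCCCc1nc(-c2cccc([N+](=O)[O-])c2)no1`: > 10000 nM, a limit of the assay
compound 3 `O=C(CCCCCCc1nc(-c2ccccc2)no1)C(F)(F)F`: 760 nM

Compound 3 gives the lowest of the two numbers in this assay; compound 1 sits higher than compound 3, beyond the scatter. The value for compound 2 is a limit of this assay and not a number. Within the data shown here, the only measured step, an at least 4.2-fold higher number from compound 1 to compound 2 (0.62 log units; beyond the scatter), alters the group on the amide-type nitrogen and not the aromatic ring, so it bears no direct weight on the change now considered. Compound 4 `O=C(CCCCCCc1nc(-c2cccc([N+](=O)[O-])c2)no1)C(F)(F)F` differs from compound 3 by nitro in place of hydrogen on an aromatic carbon; the trifluoromethyl ketone is kept. Among the measured compounds shown here, no measured pair differs only in this way. Compound 4 is expected to sit close to compound 3, with a 1.1-fold higher number from compound 3 to compound 4 (0.05 log units; within the scatter) not beyond the scatter. The estimate for compound 4 in this assay is 850 nM, range 300 nM to 2500 nM.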

Compound 4, half-maximal inhibitory concentration: 830 nM
Estimate against measurement, compound 4: 1.0-fold (0.01 log units) above, and the stated range covers the measured number.
By their numbers in this assay, from the lowest: compounds 3 and 4 (each within the scatter of the next); then compound 1. At a limit, above all of these: compound 2.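

In this assay, nitro on an aromatic carbon, meta to a large group, gives a 1.1-fold higher number from compound 3 to compound 4 (0.04 log units; within the scatter), so this position tolerates the change with the trifluoromethyl ketone kept. With the nitro group held, trifluoromethyl on the carbonyl carbon can now be read directly against hydroxyamino, a 2.9-fold lower number from compound 1 to compound 4 (0.46 log units; beyond the scatter), and against (2-aminophenyl)amino, an at least 12-fold lower number from compound 2 to compound 4 (1.08 log units; beyond the scatter). The last of these steps rests on compound 2, whose value is a limit of the assay and not a number: the limit of > 10000 nM in this assay, at which 1 of the 4 values shown sits.

On these data alone, whether an amine or a carboxylic acid on this aromatic carbon would read like nitro remains open. As far as these compounds go, the effect of a longer chain with the trifluoromethyl ketone also remains open.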